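The compounds below may be only part of what the source reports. "The series", "measured", "known", "first", "only" and "open" are said of these compounds alone.

Working notes on the series. Three compounds have numbers in a functional assay on PC-3 cells (Homo sapiens) for cytotoxicity, read by MTT assay, with a stated time of 48 h; a higher number here means a weaker inhibitor, a lower number a stronger inhibitor. Compound 1 `C=CCN(CC=C)CC(=O)N1N=C(C)CC1c1cc(Br)ccc1O` gives 3090 nM. Compound 2 `CC(=O)Oc1ccccc1C1CC(C)=NN1C(=O)CN1CCC(O)CC1` gives 25600 nM. Compound 3 `O=C(c1ccccc1)N1N=C(c2cc3ccccc3oc2=O)CC1c1ccccc1` gives 5870 nM. On these three numbers compound 3 sits second highest: its gap to compound 1 is within the scatter, so the two cannot be ordered, while its gap to compound 2, which has the higher number, lies beyond the scatter.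

Compound 4 `CC(C)(C)NCC(=O)N1N=C(c2cc3ccccc3oc2=O)CC1c1ccccc1` is not yet measured. It differs from compound 3 in one place, (((tert-butyl)amino)methyl in place of phenyl on a carbonyl carbon), a benzoyl becoming a (((tert-butyl)amino)methyl)carbonyl. Among the measured compounds shown here, no pair of measured compounds shows this change on a shared core; compounds 1 and 2 carry aminomethyl carbonyl groups but on other cores, and their values span a wide gap with neither at the low end of the set. A step of modest size is therefore expected from compound 3 to compound 4 in this assay, most likely toward a somewhat higher number, a 1.2-fold higher number from compound 3 to compound 4 (0.08 log units; within the scatter). Compound 4 is accordingly estimated at 7000 nM, with a range from 2000 nM to 25000 nM.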

Compound 4, half-maximal inhibitory concentration: 16400 nM
The estimate for compound 4 lay 2.3-fold (0.37 log units) below the measured number; the measured number falls inside the stated range.
By their numbers in this assay, from the lowest: compounds 1 and 3 (each within the scatter of the next); then compounds 4 and 2 (each within the scatter of the next).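

In this assay, among the compounds shown here, the single change on the carbonyl carbon gives a 2.8-fold higher number from compound 3 to compound 4 (0.45 log units; beyond the scatter) and is the first step that can be read at a single place. This position on the shared core is therefore sensitive to the change: two groups of equal heavy-atom count, one a six-membered aromatic ring of carbon only and the other an open chain with a hydrogen-bond donor and acceptor, do not read alike, and the benzoyl form holds the lower number. Nothing measured here accounts for the rise.

On these data alone, whether the step follows the loss of the aromatic ring or the arrival of the amine nitrogen stays open, and a cyclohexyl group on the same carbonyl carbon would separate the two. Also open, as far as these compounds go, is how a dimethylamino or morpholine group in place of the tert-butylamino part would read on this core.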